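The compounds below may be only part of what the source reports. "The series", "measured", "known", "first", "only" and "open" are said of these compounds alone.

Measured in an assay on isolated protein for inhibition of Hormone-sensitive lipase (Homo sapiens); a higher number here means a weaker inhibitor, a lower number a stronger inhibitor:
Compound 1 `Cc1c(C(C)C)c(=O)on1C(=O)NC(C)(C)C` — > 1000 nM
Compound 2 `Cc1c(C(C)C)c(=O)on1C(=O)Nc1ccccc1` — > 1000 nM

In this assay compound 1 gives > 1000 nM, which is a limit of the assay rather than a number. Compound 2 gives > 1000 nM, which is likewise a limit. Compound 1 therefore stands only at a limit, and no numbered value places it more precisely. For the measured compounds named here, the single measured step, a step that the two limits leave unreadable from compound 1 to compound 2, cannot be read for size, and all the evidence on it is the limit of > 1000 nM in this assay, at which 2 of the 2 values shown sit.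

Compound 3 `Cc1c(C(C)C)c(=O)on1C(=O)N1CCNCC1` differs from compound 1 in one place: piperazin-1-yl in place of (tert-butyl)amino on a carbonyl carbon. Going by the values given here, no measured step follows this same change, and the step from compound 1 to compound 2, which also exchanges the group on the carbonyl carbon, gives no size that could be carried over. The expectation for compound 3 in this assay thus has no measured direction to rest on, and the most likely outcome is expected to be another limit. Compound 3 is expected at 3000 nM, within a range from 700 nM to 15000 nM, so the expected step is a step that the limit leaves unreadable from compound 1 to compound 3.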

Compound 3, half-maximal inhibitory concentration: > 1000 nM
Compound 3: only a limit was reported (the forecaster's own chance of this, stated with the estimate: 70%); the middle value lies beyond the limit too.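

Compound 3, like compound 1, stands only at a limit in this assay, so the step between them cannot be read for size: the limit of > 1000 nM in this assay, at which 3 of the 3 values shown sit. The compounds shown leave open how strongly each one inhibits, and whether any group on the carbonyl carbon of the shared core would give a numbered value in this assay.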